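The source may report more compounds than this note shows. Statements on the series, on what has been measured and on what is new or still open speak of the compounds shown alone.

Working notes on the series. Compound 1 `C=CCN(C)C(=O)c1ccc(C(CC)(CC)c2ccc(OCC(=O)C(C)(C)C)c(C)c2)n1CC` gives in an assay on HL-60 cells for agonist activity at vitamin D3 receptor (Homo sapiens), read by microscopy, with a stated time of 96 h (on this read-out higher numbers stand for an effect only at larger amounts of compound and lower numbers for an effect already at smaller amounts), a value of 21600 nM. Compound 2 `CCn1c(C(=O)N(C)c2ccccc2)ccc1C(CC)(CC)c1ccc(OCC(=O)C(C)(C)C)c(C)c1` carries phenyl in place of allyl on an amide-type nitrogen; in this assay compound 2 gives 18500 nM, and the step of a 1.2-fold lower number from compound 1 to compound 2 (0.07 log units; within the scatter). Compound 3 `C=CCN(C)C(=O)c1ccc(C(CC)(CC)c2ccc(OCC(O)C(C)(C)C)c(C)c2)n1CC` in this assay gives 3950 nM, a step of a 5.5-fold lower number from compound 1 to compound 3 (0.74 log units; beyond the scatter), the lowest number among the three measured compounds. Compound 4 `CCn1c(C(=O)N(C)c2ccccc2)ccc1C(CC)(CC)c1ccc(OCC(O)C(C)(C)C)c(C)c1` is not yet measured; it stands to compound 3 as compound 2 stands to compound 1, through (phenyl in place of allyl on an amide-type nitrogen), the same change at the same place. The cores of the two pairs differ by 1-hydroxy-2,2-dimethylpropyl in place of (tert-butyl)carbonyl on a saturated chain carbon bound to an oxygen on an aromatic ring. The step from compound 3 to compound 4 is expected to be a 1.2-fold lower number from compound 3 to compound 4 (0.08 log units; within the scatter) because the same change read a 1.2-fold lower number from compound 1 to compound 2 (0.07 log units; within the scatter). Compound 4 is therefore estimated at 3300 nM, with a likely range from 1500 nM to 8000 nM.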

Compound 4, half-maximal effective concentration: 6400 nM
Compound 4: middle estimate off by 1.9-fold (0.29 log units), on the low side; low and high end bracket the measured number.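

In this assay, phenyl in place of allyl on an amide-type nitrogen now reads a 1.6-fold higher number from compound 3 to compound 4 (0.21 log units; within the scatter), and the two readings of this change do not differ: the same change on two cores in this assay, a 1.2-fold lower number (0.07 log units; within the scatter) from compound 1 to compound 2 and a 1.6-fold higher number (0.21 log units; within the scatter) from compound 3 to compound 4, 1.9-fold (0.28 log units) apart, within the scatter of two such steps

1-Hydroxy-2,2-dimethylpropyl in place of (tert-butyl)carbonyl reads a 2.9-fold lower number from compound 2 to compound 4 (0.46 log units; beyond the scatter), lowering the number on both cores, again with no difference between the two readings: the same change on two cores in this assay, a 5.5-fold lower number (0.74 log units; beyond the scatter) from compound 1 to compound 3 and a 2.9-fold lower number (0.46 log units; beyond the scatter) from compound 2 to compound 4, 1.9-fold (0.28 log units) apart, within the scatter of two such steps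

This shows that each change carried across the pair of cores among these compounds, but it does not show that either would carry to any other core, and the phenyl step cannot be told from no change on either core.

The compounds shown leave open how a benzyl or cyclohexyl group would read on the amide-type nitrogen, and how an amine or a carboxylic acid would read in place of the 1-hydroxy-2,2-dimethylpropyl group.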